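A few compounds are considered here, and "the series" means these few. Any claim that something is new, unique, unknown or untested is made for them only; others in the source may bear on it.

Measured so far:
- compound 1 `O=C1CS/C(=N/Nc2nncc3ccccc23)N1c1ccccc1` — 4.6 nM
- compound 2 `O=S(=O)(Nc1ccccn1)c1ccc(Nc2nncc3ccccc23)cc1` — 8.4 nM

Two compounds of the series have numbers in a functional assay on SF-295 cells (Homo sapiens) for antiproliferative activity, read by sulforhodamine B assay, with a stated time of 72 h; on this read-out higher numbers stand for weaker inhibition and lower numbers for stronger inhibition. Compound 1 gives 4.6 nM in this assay, and compound 2 gives 8.4 nM; the two values stand within the usual scatter of each other, so nothing separates them. Compound 2 shares the sulfonamide arrangement with the next compound.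

Compound 3 `O=S(=O)(Nc1nccs1)c1ccc(Nc2nncc3ccccc23)cc1` is not yet measured. It differs from compound 2 in one place only: 1,3-thiazol-2-yl in place of pyridin-2-yl on a sulfonamide nitrogen. For the measured compounds named here, no step between measured compounds covers this change, so there is no measured step to lean on. The two measured compounds, although different in their wider structure, both give low numbers in this assay, which argues that the shared core carries the activity and that a swap of the group on the sulfonamide nitrogen will not move the value far. The step from compound 2 to compound 3 is expected to be small, within the scatter, with no direction preferred: a 1.2-fold higher number from compound 2 to compound 3 (0.08 log units; within the scatter). Compound 3 is therefore estimated at 10 nM in this assay, with a range from 3 nM to 35 nM.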

Compound 3, half-maximal inhibitory concentration: 6.5 nM
The estimate for compound 3 lay 1.5-fold (0.19 log units) above the measured number; measured number inside the range.
By their numbers in this assay, from the lowest: compounds 1, 3 and 2 (each within the scatter of the next).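

In this assay, for the compounds shown here, the swap of 1,3-thiazol-2-yl in place of pyridin-2-yl on a sulfonamide nitrogen gives a 1.3-fold lower number from compound 2 to compound 3 (0.11 log units; within the scatter) and stays within the usual scatter; this is the first step that can be read at a single place. At this position, in this pair, a five-membered aromatic ring with 2 hetero atoms and a six-membered aromatic ring with 1 hetero atom cannot be told apart on this read-out, so the low numbers of compound 2 do not depend on the pyridin-2-yl group as such. Nothing measured on these compounds offers an explanation for this outcome.

Still open, on these data alone, is whether the value holds on the sulfonamide nitrogen with something other than these two aromatic rings, such as a longer alkyl chain, a carboxylic acid or an amine. Compound 1 differs from compound 2 and compound 3 in more than one place, so the part of compound 1 that stands where they carry the sulfonamide arrangement cannot be weighed against them.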